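From phenyl to 2-fluorophenyl: a small step expected

This account rests on a few compounds, and the source may have more. Where it says the series, first, only, none or still open, it means among the compounds named here.

In a functional assay on MCF7 cells (Homo sapiens) for inhibition, read by MTT assay, with a stated time of 72 h (on this read-out lower numbers stand for stronger inhibition and higher numbers for weaker inhibition), compound 1 `C/C1=C\CC[C@@]2(C)O[C@@H]2[C@H]2OC(=O)[C@@H](CN3CCN(C)CC3)[C@@H]2C[C@H]1O` gives 33000 nM and compound 2 `C/C1=C\CC[C@@]2(C)O[C@@H]2[C@H]2OC(=O)[C@@H](CN3CCN(c4ccccc4)CC3)[C@@H]2C[C@H]1O` gives 19000 nM. These two numbers lie within the usual scatter of each other, so compound 2 stands level with compound 1 on the data so far. Compound 3 `C/C1=C\CC[C@@]2(C)O[C@@H]2[C@H]2OC(=O)[C@@H](CN3CCN(c4ccccc4F)CC3)[C@@H]2C[C@H]1O` keeps all of compound 2 except one spot, where phenyl becomes 2-fluorophenyl fluoro in place of hydrogen on an aromatic carbon, ortho to a large group. Among the measured compounds shown here, only one measured step touches this part of the molecule, namely a 1.7-fold lower number from compound 1 to compound 2 (0.24 log units; within the scatter), with phenyl in place of methyl on an amine nitrogen in a ring. For the measured compounds named here, no measured pair tests fluoro itself. No shift beyond the scatter is therefore expected in this assay, in either direction. The expected step is a 1.1-fold lower number from compound 2 to compound 3 (0.05 log units; within the scatter). For compound 3 the estimate is 17000 nM, with an expected range of 8000 nM to 36000 nM.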

Compound 3, half-maximal inhibitory concentration: 24000 nM
The estimate for compound 3 lay 1.4-fold (0.15 log units) below the measured number; the range from low to high includes it.
By their numbers in this assay, from the lowest: compounds 2, 3 and 1 (each within the scatter of the next).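

In this assay, among the compounds shown here, fluoro on an aromatic carbon, ortho to a large group, gives a 1.3-fold higher number from compound 2 to compound 3 (0.10 log units; within the scatter) in the first test of a change on the phenyl group itself. At this spot, then, swapping a hydrogen atom for fluoro does not move the number beyond the usual variation between repeats. Replacing the methyl on the ring amine nitrogen with 2-fluorophenyl gives a 1.4-fold lower number from compound 1 to compound 3 (0.14 log units; within the scatter) and so also stays within that variation, as the change from methyl to phenyl did.

Still open, as far as these compounds go, is whether chloro, methoxy, an amine or a carboxylic acid on this same aromatic carbon would give a step beyond the scatter. No measurement shown here offers an explanation for these results.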